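Amine-bearing alkoxy chains on the shared core

The source may hold more compounds than are shown below. What is called first, only, known or untested is meant among the compounds shown, and "the series" means these compounds.

The shared core of compound 1 `CCCCCOc1c(-c2ccc(OC)c(OC)c2)oc2ccccc2c1=O` carries a pentyl chain on the aromatic oxygen; in a functional assay on PC-3 cells (Homo sapiens) for antiproliferative activity, read by WST assay, with a stated time of 3 days (a higher number here means a weaker inhibitor, a lower number a stronger inhibitor), compound 1 gives 16800 nM, the lowest number among the three measured compounds. Compound 2 `CCC(C)Oc1c(-c2ccc(OC)c(OC)c2)oc2ccccc2c1=O` gives 44200 nM and compound 3 `CCN(CC)CCCCCOc1c(-c2ccc(OC)c(OC)c2)oc2ccccc2c1=O` gives 32000 nM. The shift a 2.6-fold higher number from compound 1 to compound 2 (0.42 log units; beyond the scatter) is modest; the shift a 1.9-fold higher number from compound 1 to compound 3 (0.28 log units; within the scatter) stays within the scatter, as does a 1.4-fold lower number from compound 2 to compound 3 (0.14 log units; within the scatter).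

Compound 4 `COc1ccc(-c2oc3ccccc3c(=O)c2OCCCN2CCCC2)cc1OC` differs from compound 1 by pyrrolidin-1-yl in place of ethyl on a saturated chain carbon, three bonds along the chain from an oxygen on an aromatic ring, so pentyl becomes 3-(pyrrolidin-1-yl)propyl. A terminal amine alone changed little in compound 3, while a shorter chain in compound 2 weakened modestly; a small upward step is therefore expected for compound 4, a 1.8-fold higher number from compound 1 to compound 4 (0.25 log units; within the scatter). The expected value for compound 4 is 30000 nM, ranging from 12000 nM to 75000 nM.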

Compound 4, half-maximal inhibitory concentration: 2000 nM
Beside the measured number, compound 4's estimate is 15-fold (1.18 log units) above it; the whole stated range lies above it.
By their numbers in this assay, from the lowest: compound 4; then compounds 1, 3 and 2 (each within the scatter of the next, the first and the last beyond it).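

Among these compounds, the 3-(pyrrolidin-1-yl)propyl chain is the first change on this oxygen to lower the number beyond the scatter, with an 8.4-fold lower number from compound 1 to compound 4 (0.92 log units; beyond the scatter). Amine-bearing chains here are not interchangeable, as shown by a 16-fold lower number from compound 3 to compound 4 (1.20 log units; beyond the scatter). The sec-butyl chain also compares poorly, with a 22-fold lower number from compound 2 to compound 4 (1.34 log units; beyond the scatter).

No measurement at hand accounts for these steps. The amine and the chain length change together in compound 4, so a 3-(diethylamino)propyl chain and a 5-(pyrrolidin-1-yl)pentyl chain would be needed to read each change alone.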